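Replacing a methoxyphenyl ketone with a methylphenyl ketone

The compounds below may be only part of what the source reports. "The series", "measured", "known", "first", "only" and "open" are said of these compounds alone.

Compound 1 `C#CCOc1ccc(/C=C/C(=O)c2cccc(OC)c2)cc1OC` carries a propargyl ether and a methoxy group on one ring and a 3-methoxyphenyl on the carbonyl carbon. In a functional assay on CCRF-CEM cells (Homo sapiens) for cytotoxicity, with a stated time of 72 h (on this read-out lower numbers stand for stronger inhibition and higher numbers for weaker inhibition), compound 1 gives 5590 nM. Compound 3 `C#CCOc1ccc(/C=C/C(=O)c2ccc(OC)c(OC)c2)cc1OC` differs from it by a methoxy in place of hydrogen on an aromatic carbon and gives 8650 nM in this assay; the step of a 1.5-fold higher number from compound 1 to compound 3 (0.19 log units; within the scatter) lies within the scatter, so the two numbers are not distinguished. Compound 2 `C#CCOc1ccc(/C=C/C(=O)c2ccc(CC=C(C)C)cc2)cc1OC` is reported in this assay only as a limit, > 50000 nM, and so adds no number; this is the limit of > 50000 nM in this assay, at which 1 of the 3 values shown sits.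

Compound 4 `C#CCOc1ccc(/C=C/C(=O)c2ccccc2C)cc1OC` is not yet measured. It differs from compound 1 in one place: 2-methylphenyl in place of 3-methoxyphenyl on a carbonyl carbon. Within the data shown here, the only measured step touching the ring on the carbonyl carbon is the one from compound 1 to compound 3, which added a methoxy and stayed within the scatter. Among the measured compounds shown here, no measured step removes the methoxy or introduces a methyl on that ring, so the evidence is thin. He therefore expects the step of a 1.4-fold higher number from compound 1 to compound 4 (0.16 log units; within the scatter) to stay modest, with no clear direction beyond the scatter. His estimate for compound 4 in this assay is 8000 nM, within the range 2500 nM to 30000 nM.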

Compound 4, half-maximal inhibitory concentration: 6950 nM
The estimate for compound 4 lay 1.2-fold (0.06 log units) above the measured number; low and high end bracket the measured number.
By their numbers in this assay, from the lowest: compounds 1, 4 and 3 (each within the scatter of the next). At a limit, above all of these: compound 2.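

In this assay, the ring on the carbonyl carbon has now been exchanged as a whole group, not only given an added methoxy, and the reading is a 1.2-fold higher number from compound 1 to compound 4 (0.09 log units; within the scatter). With 2-methylphenyl in place of 3-methoxyphenyl, the group on the carbonyl carbon has no hydrogen-bond acceptor, yet compound 4 is not distinguished from compound 1, so for this pair the methoxy oxygen is not required to keep the number at this level. Nothing measured here accounts for why this exchange leaves the number where it is.

Compound 2 is a limit of the assay, > 50000 nM, and not a number, so it gives no measured size for any step on this ring. Every step shown stays within the scatter, which leaves open whether an amine or a carboxylic acid on the ring on the carbonyl carbon would move the number beyond the scatter in either direction.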